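A Nitrile Side Chain on a Flat Series

A few compounds are considered here, and "the series" means these few. Any claim that something is new, unique, unknown or untested is made for them only; others in the source may bear on it.

Of the compounds shown here, three sharing one core have so far been tested in a functional assay on J82 cells (Homo sapiens) for cytotoxicity, read by colorimetric assay and MTT assay; on this read-out lower numbers stand for stronger inhibition and higher numbers for weaker inhibition. Compound 1 `CCOC(=O)Cn1c(=O)c(-c2ccc(OC)cc2)cc2c(OC)cc(OC)cc21` gives 10000 nM, compound 2 `CCN(CC)C(=O)Cn1c(=O)c(-c2ccc(OC)cc2)cc2c(OC)cc(OC)cc21` gives 10000 nM, and compound 3 `COc1ccc(-c2cc3c(OC)cc(OC)cc3n(CC(=O)OCc3ccccc3)c2=O)cc1` gives 10000 nM. Compound 3 therefore stands level with the other two, and the series shows no spread yet.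

The next candidate is compound 4 `COc1ccc(-c2cc3c(OC)cc(OC)cc3n(CCC#N)c2=O)cc1`. The change is cyanomethyl in place of benzyloxycarbonyl on a saturated chain carbon bound to an aromatic nitrogen: cyanomethyl in place of benzyloxycarbonyl, on a saturated chain carbon bound to an aromatic nitrogen. Read one bond further out, (benzyloxycarbonyl)methyl becomes 2-cyanoethyl.

For the measured compounds named here, three measured steps bear on this, since each alters the same side chain. Diethylamino in place of ethoxy gives no change at the digits printed from compound 1 to compound 2 (within the scatter). Phenyl in place of methyl gives no change at the digits printed from compound 1 to compound 3 (within the scatter). Benzyloxy in place of diethylamino gives no change at the digits printed from compound 2 to compound 3 (within the scatter). All three steps are empty of change, yet each keeps the carbonyl, so none of them tests a side chain ending in a nitrile. That leaves real uncertainty, but the data offer no direction, so no shift beyond the scatter is expected.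

The expected outcome is no change at the digits printed from compound 3 to compound 4 (within the scatter). For compound 4 the estimated value is 10000 nM, with an expected range from 4000 nM to 20000 nM.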

Compound 4, half-maximal inhibitory concentration: 10000 nM
Compound 4: the middle estimate sits on the measured number at the digits printed, and the stated range covers the measured number.
By their numbers in this assay, from the lowest: compounds 1, 2, 3 and 4 (each within the scatter of the next).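

In this assay, putting cyanomethyl in place of benzyloxycarbonyl on a saturated chain carbon bound to an aromatic nitrogen gives no change at the digits printed from compound 3 to compound 4 (within the scatter); against the other two side chains, the same swap gives no change at the digits printed from compound 2 to compound 4 (within the scatter) for diethylcarbamoyl and no change at the digits printed from compound 1 to compound 4 (within the scatter) for ethoxycarbonyl. These steps reach further than the earlier ones, which all kept the carbonyl: here the carbonyl gives way to a nitrile, and a group of 10 heavy atoms with an aromatic ring gives way to one of 3 heavy atoms with no ring. So at this position, neither the carbonyl nor the ring of benzyloxycarbonyl is needed for compound 4 to read the same as compound 3, although no data on hand say why these compounds read alike.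

The compounds shown leave open whether a side chain ending in an amine or a carboxylic acid, or a longer chain at the same nitrogen, would read differently. With all four compounds level, they also do not show which change to the side chain or to the shared core, such as replacing a methoxy group with a hydroxyl, would lower the number in this assay at all.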